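Swapping Methyl for Isopropyl on the Aryl Ring

A few compounds are considered here, and "the series" means these few. Any claim that something is new, unique, unknown or untested is made for them only; others in the source may bear on it.

Of the compounds shown here, three sharing one core have been measured in a functional assay on a subcellular fraction from brain (Rattus norvegicus) for inhibition, read by scintillation counting, with a stated time of 5 min; a lower number here means a stronger inhibitor, a higher number a weaker inhibitor. Compound 1 `Cc1cc(C)c(NC2=NCCC3(CCCCC3)S2)c(C)c1` gives 9300 nM, compound 3 `Cc1cccc(C(C)C)c1NC1=NCCC2(CCCCC2)S1` gives 20900 nM, and compound 2 `Cc1ccc(NC2=NCCC3(CCCCC3)S2)cc1` gives 31600 nM. Compound 2 therefore stands at the high end of the three: compound 1 sits at a clearly lower number, while compound 3 lies within the usual scatter of compound 2. Compound 4 `CC(C)c1ccc(NC2=NCCC3(CCCCC3)S2)cc1` is the next candidate; it differs from compound 2 by isopropyl in place of methyl on an aromatic carbon. Among the compounds with values here, no measured pair shows this change, so there is no yardstick for its size. The expected step in this assay is small, downward or none beyond the scatter: a 1.3-fold lower number from compound 2 to compound 4 (0.10 log units; within the scatter). Compound 4 is thus estimated at 25000 nM, with a range from 8000 nM to 80000 nM.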

Compound 4, half-maximal inhibitory concentration: 6200 nM
Estimate against measurement, compound 4: 4.0-fold (0.61 log units) above; measured number below the stated range.
By their numbers in this assay, from the lowest: compounds 4 and 1 (each within the scatter of the next); then compounds 3 and 2 (each within the scatter of the next).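

Isopropyl in place of methyl on an aromatic carbon, para to a large group, gives the first single-change comparison in this series: in this assay it brings a 5.1-fold lower number from compound 2 to compound 4 (0.71 log units; beyond the scatter) and this modest step lies beyond the scatter. The number at this position therefore depends on the group placed there, with the larger group going with the lower number in this one pair. Nothing measured here explains the step.

As far as these compounds go, whether a longer chain would lower the number further remains open. So does how an amine or a carboxylic acid at this position would compare.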